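Swapping a phenyl substituent for a pyrimidine on the core

This account rests on a few compounds, and the source may have more. Where it says the series, first, only, none or still open, it means among the compounds named here.

Compound 1, with the structure `CC#C[C@@H](Cc1nnn[nH]1)c1ccc(OCc2ccc3scc(-c4cc(OCCOC)ccc4C)c3c2)cc1`, was tested in a functional assay on cells for agonist activity at Free fatty acid receptor 1 (Homo sapiens), read by FLIPR and calcium flux (on this read-out lower numbers stand for an effect already at smaller amounts and higher numbers for an effect only at larger amounts of compound), where compound 1 gives 85 nM. Compound 2, drawn as `CC#C[C@@H](Cc1nnn[nH]1)c1ccc(OCc2ccc3sc(C#N)c(-c4ccccc4C)c3c2)cc1`, was measured in this assay as well; in this assay compound 2 gives 16 nM. Of these two numbers, compound 1 stands at the higher one, and the gap to compound 2 lies beyond the usual scatter of repeated measurements. Compound 3, with the structure `CC#C[C@@H](Cc1nnn[nH]1)c1ccc(OCc2ccc3scc(-c4cncnc4C)c3c2)cc1`, has not yet been measured. It differs from compound 1 in a single place: 4-methylpyrimidin-5-yl in place of 5-(2-methoxyethoxy)-2-methylphenyl on an aromatic carbon. Going by the values given here, no measured pair in this set shows this particular change, so its effect can only be guessed. The expectation is a modest move toward a higher number, estimated as a 2.4-fold higher number from compound 1 to compound 3 (0.37 log units; beyond the scatter). Compound 3 is therefore expected to give about 200 nM in this assay, within a range from 50 nM to 800 nM.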

Compound 3, half-maximal effective concentration: 37 nM
Estimate against measurement, compound 3: 5.4-fold (0.73 log units) above; the whole stated range lies above it.
By their numbers in this assay, from the lowest: compound 2; then compound 3; then compound 1.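

In this assay, the aromatic carbon two ring bonds from the ring sulfur tolerates a clear change of group: putting 4-methylpyrimidin-5-yl in place of 5-(2-methoxyethoxy)-2-methylphenyl gives a 2.3-fold lower number from compound 1 to compound 3 (0.36 log units; beyond the scatter). The substituent shrinks from 12 heavy atoms to 7, so on this core neither the 2-methoxyethoxy chain nor a ring of carbon only is required to reach this level of activity. Nothing available here accounts for the shift in the number.

The swap changes the ring and removes the chain in one step, so the share of each in the result stays unresolved. A 4-methylpyridin-3-yl group, with a single ring nitrogen, or a pyrimidine carrying an amine at this same place would help show how far the ring nitrogens matter.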